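The source may report more compounds than this note shows. Statements on the series, on what has been measured and on what is new or still open speak of the compounds shown alone.

Among the measured compounds shown here, in an ADME assay on microsomes from liver (Homo sapiens) for metabolic stability (a lower number here means slower removal, a higher number faster removal of the compound), compound 3 `Cc1ccc([C@H](C)NC(=O)Cn2nnc3ccccc3c2=O)c(F)c1` gives 28 mL/min/kg, the only true number so far. Compound 1 `Cc1ccc([C@H](C)NC(=O)Cn2nnc3ccccc3c2=O)nc1` gives < 9.9 mL/min/kg, which is a limit of the assay and not a number. Compound 2 `Cc1ccc([C@H](C)NC(=O)Cn2nnc3ccccc3c2=O)cn1` gives < 9.9 mL/min/kg, again a limit. Compound 4 `C[C@H](NC(=O)Cn1nnc2ccccc2c1=O)c1nccs1` is not yet measured and differs from compound 3 in one place: 1,3-thiazol-2-yl in place of 2-fluoro-4-methylphenyl on a saturated chain carbon bound to an amide-type nitrogen and a saturated chain carbon. There, 1,3-thiazol-2-yl takes the place of 2-fluoro-4-methylphenyl on a saturated chain carbon bound to an amide-type nitrogen and a saturated chain carbon. For the measured compounds named here, two measured steps bear on this, both bringing in the 2-fluoro-4-methylphenyl group: an at least 2.8-fold higher number from compound 1 to compound 3 (0.45 log units; beyond the scatter) and an at least 2.8-fold higher number from compound 2 to compound 3 (0.45 log units; beyond the scatter). Both are rises beyond the scatter. Going by the values given here, compound 4 reverses that kind of swap, giving up the aromatic ring of carbon only for a ring with hetero atoms, although no measured compound carries a five-membered ring. A fall in this assay is therefore expected, an estimated 2.3-fold lower number from compound 3 to compound 4 (0.37 log units; beyond the scatter). For compound 4 the expected clearance is 12 mL/min/kg, with an estimated range from 8 mL/min/kg to 22 mL/min/kg.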

Compound 4, clearance: < 9.9 mL/min/kg
Compound 4: no number, only a limit; the forecaster's own chance of this, stated with the estimate: 40%; at least 1.2-fold (0.08 log units) between middle value and limit.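

In this assay the swap to 1,3-thiazol-2-yl gives an at least 2.8-fold lower number from compound 3 to compound 4 (0.45 log units; beyond the scatter), so a five-membered aromatic ring with 2 hetero atoms does at this place what the two methylpyridinyl groups did earlier, and a low reading here does not depend on a six-membered ring. Among the four compounds, only the one with a ring of carbon alone, compound 3, rises clear of the limit, and none goes against this pattern. The steps linking compound 4 to compound 1 and compound 2 cannot be read, because all three compounds end at the same limit: the limit of < 9.9 mL/min/kg in this assay, at which 3 of the 4 values shown sit.

From the compounds shown here alone, since the swap removes the fluorine, the methyl and the carbon-only ring together, which of them matters stays open. A plain 4-methylphenyl or 2-fluorophenyl group at this place would begin to separate them.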